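The source may report more compounds than this note shows. Statements on the series, on what has been measured and on what is new or still open speak of the compounds shown alone.

Compound 1 `Cc1ccc(S(=O)(=O)/C(=C/c2sccc2C)C(=O)c2ccc(Cl)cc2)cc1` and compound 2 `COc1ccccc1/C=C(\C(=O)c1ccc(Br)cc1)S(=O)(=O)c1ccc(C)cc1` have both been tested in a functional assay on DU-145 cells (Homo sapiens) for inhibition, read by trypan blue exclusion, with a stated time of 96 h; a lower number here means a stronger inhibitor of growth, a higher number a weaker inhibitor of growth. There, compound 1 gives 10000 nM. Compound 2 gives 1000 nM, the lower of the two numbers and, beyond the scatter, the stronger inhibitor of growth. Compound 3 `Cc1ccc(S(=O)(=O)/C(=C/c2sccc2C)C(=O)c2ccc(Br)cc2)cc1` has 3-methylthiophen-2-yl in place of 2-methoxyphenyl on a double-bonded chain carbon bound to a double-bonded chain carbon. Compound 1 also carries 3-methylthiophen-2-yl, so a moderate weakening beyond the scatter is expected in this assay. The expected change is a 4.0-fold higher number from compound 2 to compound 3 (0.60 log units; beyond the scatter). Compound 3 is estimated at 4000 nM, within a range of 1200 nM to 12000 nM.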

Compound 3, concentration for 50% growth inhibition: 25000 nM
Compound 3: the middle estimate sits 6.3-fold (0.80 log units) below what was measured; the measured number lies above the stated range.
By their numbers in this assay, from the lowest: compound 2; then compound 1; then compound 3.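

Putting 3-methylthiophen-2-yl in place of 2-methoxyphenyl on a double-bonded chain carbon bound to a double-bonded chain carbon gives a 25-fold higher number from compound 2 to compound 3 (1.40 log units; beyond the scatter) in this assay and is a large step, so growth inhibition depends strongly on the group at this position. Bromo in place of chloro on an aromatic carbon gives a 2.5-fold higher number from compound 1 to compound 3 (0.40 log units; beyond the scatter) and is a smaller step, though still beyond the scatter. On these data alone, whether an amine or a carboxylic acid on the ring at this position would give a lower number remains open. No available evidence explains either step.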